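Replacing the indole of compound 1 with a methylated indazole

The compounds below may be only part of what the source reports. "The series", "measured", "known", "first", "only" and "open" are said of these compounds alone.

Compound 1 `COc1cc(-c2ccnc3cc(-c4c[nH]c5ccccc45)nn23)cc(OC)c1OC` carries a 1H-indol-3-yl group on its shared core. Within the data shown here, in a functional assay on B16-F0 cells (Mus musculus) for inhibition, read by CCK-8 assay, with a stated time of 48 h (a higher number here means a weaker inhibitor, a lower number a stronger inhibitor), compound 1 gives 40 nM, the lower of the two numbers recorded; its only measured neighbour is compound 2 `COc1cc(-c2ccnc3cc(-c4ccc(Cl)cc4)nn23)cc(OC)c1OC`, which in this assay gives 4090 nM, a step of a 100-fold higher number from compound 1 to compound 2 (2.01 log units; beyond the scatter). Compound 3 `COc1cc(-c2ccnc3cc(-c4ccc5cnn(C)c5c4)nn23)cc(OC)c1OC` has not been measured; it differs from compound 1 in that (1-methyl-1H-indazol-6-yl in place of 1H-indol-3-yl on an aromatic carbon). Among the measured compounds shown here, the only step that bears on this change is the one from compound 1 to compound 2: an exchange of the indole for a single aromatic ring, which came with a large loss. Compound 3 keeps a bicyclic aromatic group but gives up the 1H-indol-3-yl group and its hydrogen-bond donor, so the step is expected to lie between no change and that large loss, toward a higher number: a 10-fold higher number from compound 1 to compound 3 (1.00 log units; beyond the scatter). Compound 3 is therefore estimated at 400 nM, with a range from 80 nM to 2500 nM.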

Compound 3, half-maximal inhibitory concentration: 1000 nM
Compound 3: the middle estimate sits 2.5-fold (0.40 log units) below what was measured; the range from low to high includes it.
By their numbers in this assay, from the lowest: compound 1; then compound 3; then compound 2.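

In this assay, the bicyclic 1-methyl-1H-indazol-6-yl group does not take the place of the 1H-indol-3-yl group without a large loss (a 25-fold higher number from compound 1 to compound 3 (1.40 log units; beyond the scatter)). It still stands ahead of the 4-chlorophenyl group, though only modestly (a 4.1-fold lower number from compound 2 to compound 3 (0.61 log units; beyond the scatter)), so at this position a second aromatic ring does not by itself recover the number seen with the indole. Nothing given here accounts for either step.

Compound 3 leaves the hydrogen-bond donor of the indole, adds a ring nitrogen and a methyl group, and changes the ring atom that carries the bond to the core, all in one step, and the compounds shown do not separate these changes. From the compounds shown here alone, whether a 1-methyl-1H-indol-3-yl group or an unmethylated 1H-indazol-6-yl group would keep the lower number remains open.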